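The source may hold more compounds than are shown below. What is called first, only, known or untested is meant among the compounds shown, and "the series" means these compounds.

In a functional assay on the whole organism (plasma, strain Wistar) with Rattus norvegicus as the target, with a stated time of 15 days, at a dose of 30 mg/kg by the oral route (on this read-out lower numbers stand for a weaker effect and higher numbers for a stronger effect at the one dose given), compound 3 `O=C1NC(=O)/C(=C/c2ccc(OCCSc3nnc(-c4ccccc4[N+](=O)[O-])[nH]3)cc2)S1` gives 20.1%. Compound 1 `O=C1NC(=O)/C(=C/c2ccc(OCc3csc(-c4ccccc4)n3)cc2)S1` gives 22.6%, and compound 2 `O=C1NC(=O)/C(=C/c2ccc(OCCSc3nnc(-c4ccc([N+](=O)[O-])cc4)[nH]3)cc2)S1` gives 16%; the number for compound 3 sits second among the three, though both gaps to it lie within the scatter. Compound 4 `COc1ccc(-c2nnc(SCCOc3ccc(/C=C4\SC(=O)NC4=O)cc3)[nH]2)cc1` differs from compound 3 in one place: 4-methoxyphenyl in place of 2-nitrophenyl on an aromatic carbon. Among the measured compounds shown here, the only measured step that bears on this is an exchange of one aromatic group for another at the same place, a number 4.1 percentage points higher from compound 2 to compound 3 (within the scatter), which lay within the scatter. A swap of the same kind in this assay is therefore expected to give no step beyond the scatter, a number 0.1 percentage points lower from compound 3 to compound 4 (within the scatter). Compound 4 is estimated at 20%, with a likely range from 9% to 31%.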

Compound 4, a percentage reported as activity, at one dose (the size of the read-out at that dose, not a potency): 40%
The estimate for compound 4 lay 20 percentage points below the measured number; measured number outside the range, above it.
By their numbers in this assay, from the lowest: compounds 2, 3 and 1 (each within the scatter of the next); then compound 4.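

In this assay, the group on this aromatic carbon of the five-membered ring can matter: the two nitrophenyl groups stay within the scatter of each other, yet 4-methoxyphenyl in place of 2-nitrophenyl gives a number 19.9 percentage points higher from compound 3 to compound 4 (beyond the scatter). Going from 4-nitrophenyl to 4-methoxyphenyl, methoxy in place of nitro gives a number 24 percentage points higher from compound 2 to compound 4 (beyond the scatter), so the step appears with either nitrophenyl group as the starting point. Nothing measured here explains the rise. As far as these compounds go, it remains open whether a hydroxy group, an amine or 2-methoxyphenyl at this place would give a similar number.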